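Permeability notes: nitro in place of trifluoromethyl

This account rests on a few compounds, and the source may have more. Where it says the series, first, only, none or still open, it means among the compounds named here.

Of the compounds shown here, three have been measured in an ADME assay for permeability, using PAMPA; a higher number here means that the compound crosses the layer faster, a lower number that the compound crosses the layer more slowly. Compound 1 `O=C(Nc1ccc([N+](=O)[O-])cc1)c1cc(Cl)ccc1O`, compound 2 `O=C(Nc1ccc(C(F)(F)F)cc1)c1cc(Cl)ccc1O` and compound 3 `O=C(Nc1ccccc1C(F)(F)F)c1cc(Cl)ccc1O` share one core and differ in the group carried on the six-membered aromatic ring of carbon only and in where that group sits. In this assay compound 1 gives 127 10^-6 cm/s. In this assay compound 3 gives 26 10^-6 cm/s. For compound 2 this assay reports a limit and not a number, < 22.3 10^-6 cm/s. Compound 2 thus sits at the limit of < 22.3 10^-6 cm/s in this assay, at which 1 of the 3 values shown sits.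

Going by the values given here, the one counted step is an at least 5.6-fold higher number from compound 2 to compound 1 (0.75 log units; beyond the scatter), the change being (nitro in place of trifluoromethyl on an aromatic carbon). Between compound 2 and compound 3 the difference between the two cores is not broken down here; their values show the pair in the same low region, with compound 2 only at a limit.

Compound 4 `O=C(Nc1ccccc1[N+](=O)[O-])c1cc(Cl)ccc1O` is not yet measured. It arises from compound 3 by nitro in place of trifluoromethyl on an aromatic carbon. Among the compounds with values here, this is the same kind of change as the one from compound 2 to compound 1, not the same: there the place is para to a large group, here it is ortho to a large group. Resting on compound 3 at 26 10^-6 cm/s and on the measured step from compound 2 to compound 1, the step from compound 3 to compound 4 in this assay is expected to be a 3.8-fold higher number from compound 3 to compound 4 (0.59 log units; beyond the scatter). Compound 4 is therefore estimated at 100 10^-6 cm/s, between 40 10^-6 cm/s and 220 10^-6 cm/s.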

Compound 4, apparent permeability in the ADME assay: 153 10^-6 cm/s
Compound 4: middle estimate off by 1.5-fold (0.18 log units), on the low side; low and high end bracket the measured number.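

In the ADME assay compound 3 gives 26 10^-6 cm/s and compound 4 gives 153 10^-6 cm/s; the new step is a 5.9-fold higher number from compound 3 to compound 4 (0.77 log units; beyond the scatter), so nitro in place of trifluoromethyl on an aromatic carbon gives the higher number on this core too. Set beside the earlier step, the direction is the same on both cores: the same change on two cores in the ADME assay, an at least 5.6-fold higher number (0.75 log units; beyond the scatter) from compound 2 to compound 1 and a 5.9-fold higher number (0.77 log units; beyond the scatter) from compound 3 to compound 4; the limit leaves it open whether they differ

In the ADME assay compound 2 stands at a limit and not a number, < 22.3 10^-6 cm/s, so two pairs show a shared direction but not a shared size, and they establish no rule for other cores in the series.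

In a physicochemical assay for solubility (a higher number here means a more soluble compound, a lower number a less soluble compound), compound 3 stands at a limit and not a number, > 47 ug/mL. In the physicochemical assay compound 4 gives 15.4 ug/mL. As far as these compounds go, in the physicochemical assay the same change gives an at least 3.0-fold lower number from compound 3 to compound 4 (0.48 log units; beyond the scatter), and whether that step carries over to the pair of compound 2 and compound 1 stays open. Also open, from the compounds shown here alone, is whether an amine, a nitrile or a carboxylic acid in the same place would give a number in the ADME assay closer to that of nitro or to that of trifluoromethyl, and whether the step from trifluoromethyl to nitro would hold on a core with another group in place of the chlorine.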